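The source may hold more compounds than are shown below. What is called first, only, known or untested is meant among the compounds shown, and "the series" means these compounds.

Measured so far:
Compound 1 `O=c1cc(/C=N\O)c2c(OCc3ccccc3)cc(OCc3ccccc3)cc2o1`, which in a functional assay, read by spectrophotometry, with a stated time of 5 min (a higher number here means a weaker inhibitor, a lower number a stronger inhibitor), gives only a limit of the assay, > 2000000 nM.
Compound 2 `O=c1cc(/C=N\O)c2ccc(OCc3ccccc3)cc2o1`, which gives only a limit of the assay, > 2000000 nM.

Compound 1 therefore stands at no number at all, only at the limit (the limit of > 2000000 nM in this assay, at which 2 of the 2 values shown sit). Within the data shown here, the single measured step, a step that the two limits leave unreadable from compound 1 to compound 2, cannot be read because both ends rest at the limit of > 2000000 nM in this assay, at which 2 of the 2 values shown sit. Compound 3 `O=c1cc(/C=N\Nc2ccccc2)c2c(OCc3ccccc3)cc(OCc3ccccc3)cc2o1` differs from compound 1 by anilino in place of hydroxy on a double-bonded nitrogen. No measured step bears on that change, so nothing shown gives its direction or size. Compound 3 is expected at 2000000 nM, within 300000 nM to 10000000 nM, most likely again reported only as a limit. That estimate means an expected step of a number no higher from compound 1 to compound 3 (the limit leaves the size open), not beyond the scatter.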

Compound 3, half-maximal inhibitory concentration: 303000 nM
The estimate for compound 3 lay 6.6-fold (0.82 log units) above the measured number; the range from low to high includes it.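

In this assay, anilino in place of hydroxy on a double-bonded nitrogen brings an at least 6.6-fold lower number from compound 1 to compound 3 (0.81 log units; beyond the scatter), so a change at this position can make the inhibitor measurably stronger. The step from compound 1 to compound 2 cannot be read, and compound 3 is the first here to give a number rather than a limit, which leaves its step with a minimum size only: the limit of > 2000000 nM in this assay, at which 2 of the 3 values shown sit.

As far as these compounds go, whether a smaller group in the same place, such as amino or methoxy, would also lower the number remains open. So does whether anilino would give a similar step on the core of compound 2.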